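The compounds below may be only part of what the source reports. "The series", "measured", "known", "first", "only" and "open" are said of these compounds alone.

Measured so far:
compound 1, `COc1ccc(/C=C/C(=O)c2cccc(-c3cccc(F)c3)c2)cc1`, 4510 nM
compound 2, `COc1cc(/C=C/C(=O)c2ccc(N)c(-c3ccc(F)cc3)c2)cc(OC)c1OC`, 6120 nM
compound 3, `COc1ccc(/C=C/C(=O)c2cccc(-c3cccc(F)c3)c2)cc1OC`, 2970 nM

In a functional assay on SW480 cells (Homo sapiens) for cytotoxicity, read by sulforhodamine B assay, with a stated time of 48 h (a higher number here means a weaker inhibitor, a lower number a stronger inhibitor), compound 3 gives 2970 nM, while compound 1 gives 4510 nM. The change between them is hydrogen in place of methoxy on an aromatic carbon, and it made a 1.5-fold higher number from compound 3 to compound 1 (0.18 log units; within the scatter). Compound 4, `COc1ccc(/C=C/C(=O)c2ccc(N)c(-c3ccc(F)cc3)c2)cc1OC`, has not yet been measured in this assay. It differs from compound 2 by hydrogen in place of methoxy on an aromatic carbon; the surroundings differ from the earlier case in that the place is also meta to a methoxy group, so this is the same kind of change rather than the same one. The difference between the cores of compound 2 and compound 3 is not broken down here. Resting on the step from compound 3 to compound 1, the change from compound 2 to compound 4 is expected to make a 1.3-fold higher number from compound 2 to compound 4 (0.12 log units; within the scatter). Compound 4 is therefore estimated at 8000 nM, between 4000 nM and 16000 nM.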

Compound 4, half-maximal inhibitory concentration: 6640 nM
Compound 4: middle estimate off by 1.2-fold (0.08 log units), on the high side; measured number inside the range.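

In this assay, hydrogen in place of methoxy on an aromatic carbon gives a 1.1-fold higher number from compound 2 to compound 4 (0.04 log units; within the scatter), and this step can be set beside the one on the other core: the same change on two cores in this assay, a 1.5-fold higher number (0.18 log units; within the scatter) from compound 3 to compound 1 and a 1.1-fold higher number (0.04 log units; within the scatter) from compound 2 to compound 4, 1.4-fold (0.15 log units) apart, within the scatter of two such steps. On these two cores, then, the change carries over with no difference that can be told from the scatter, and neither step lies beyond it. Going by these compounds alone, this rests on only two pairs, so it does not show that the step would hold on any other core, and it gives no reason for the result.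

The compounds shown leave open what a hydroxyl group, a chlorine atom or a longer ethoxy chain would give at this place on either core.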